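The source may report more compounds than this note shows. Statements on the series, on what has been measured and on what is new or still open speak of the compounds shown alone.

Working notes on the series in a functional assay on MDA-MB-435 cells (Homo sapiens) for cytotoxicity, read by MTT assay, with a stated time of 72 h; on this read-out lower numbers stand for stronger inhibition and higher numbers for weaker inhibition. Compound 1 `CS(=O)(=O)Oc1c(C(=O)NCc2ccc(F)cc2)nc(Br)c2cccnc12` reads > 20000 nM, a limit of the assay. Compound 3 `C[C@@H](Nc1c(C(=O)NCc2ccc(F)cc2)nc(Br)c2cccnc12)c1ccccc1` stands at > 20000 nM, also a limit and not a number. Going by the values given here, compound 2 `Nc1cccc(Nc2c(C(=O)NCc3ccc(F)cc3)nc(Br)c3cccnc23)c1` gives 8000 nM, the only true number so far. The next structure is compound 4 `NCCCNc1c(C(=O)NCc2ccc(F)cc2)nc(Br)c2cccnc12`, with 3-aminopropyl in place of 1-phenylethyl on a nitrogen on an aromatic ring. The closest guides are an at least 2.5-fold higher number from compound 2 to compound 3 (0.39 log units; beyond the scatter) and an at least 2.5-fold lower number from compound 1 to compound 2 (0.39 log units; beyond the scatter), both modest and both tied to compound 2, whose 3-aminophenyl also carries an amino group. A modest move to a lower number is therefore expected in this assay, an estimated at least 2.8-fold lower number from compound 3 to compound 4 (0.45 log units; beyond the scatter). The estimate for compound 4 is 7000 nM, with an expected range of 2000 nM to 20000 nM.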

Compound 4, half-maximal inhibitory concentration: 5000 nM
For compound 4 the middle estimate is 1.4-fold (0.15 log units) above the measured one; low and high end bracket the measured number.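

With 3-aminopropyl on this nitrogen on an aromatic ring, the series gives a second true number, an at least 4.0-fold lower number from compound 3 to compound 4 (0.60 log units; beyond the scatter) and an at least 4.0-fold lower number from compound 1 to compound 4 (0.60 log units; beyond the scatter), though both steps start from a limit of the assay: the limit of > 20000 nM in this assay, at which 2 of the 4 values shown sit. With a 1.6-fold lower number from compound 2 to compound 4 (0.20 log units; within the scatter), 3-aminopropyl and 3-aminophenyl cannot be told apart, so a ring on this nitrogen is not needed for a readable value. Among the compounds shown, only those carrying an amino group in the substituent give a number.

Open, going by these compounds, is whether the amino group or the chain matters, as 1-phenylethyl and 3-aminopropyl differ in both. A plain propyl group, a longer chain ending in an amine, or a carboxylic acid at the chain end would separate these.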